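This account rests on a few compounds, and the source may have more. Where it says the series, first, only, none or still open, it means among the compounds named here.

Values in an assay on HEK293 cells for inhibition of kynurenine 3-monooxygenase (Homo sapiens), read by LC-MS, with a stated time of 20 h; a lower number here means a stronger inhibitor, a higher number a weaker inhibitor:
compound 1 `O=C(O)CCn1c(=O)oc2cc(Cl)c(Cl)cc21`, 2000 nM
compound 2 `COc1cc2oc(=O)n(CCC(=O)O)c2cc1Cl`, 5010 nM

For the measured compounds named here, compound 2 stands at the highest of the two numbers in this assay; its nearest neighbour is compound 1, and the single measured step, a 2.5-fold higher number from compound 1 to compound 2 (0.40 log units; beyond the scatter), separates the two. That step is the only one in the set, and it concerns a different site from the one changed next.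

Compound 3 `C[C@@H](Oc1cc2oc(=O)n(CCC(=O)O)c2cc1Cl)c1ncco1` differs from compound 2 by a group of 7 heavy atoms (5 carbon, 1 nitrogen, 1 oxygen; one five-membered aromatic ring with 2 hetero atoms) in place of one carbon atom, on an oxygen on an aromatic ring. Going by the values given here, no measured step covers an exchange of this kind: the one step available, a 2.5-fold higher number from compound 1 to compound 2 (0.40 log units; beyond the scatter), swaps a chloro for a methoxy on an aromatic carbon and says nothing about what happens when the methyl on the ether oxygen is replaced by a larger group. The expectation therefore rests only on the shared core and the unchanged remainder of compound 2, with the direction open. Compound 3 is expected to give about 3500 nM in this assay, with a range of 900 nM to 14000 nM. The estimated step of a 1.4-fold lower number from compound 2 to compound 3 (0.16 log units; within the scatter) is expected to sit near the scatter, leaning slightly towards a lower number.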

Compound 3, half-maximal inhibitory concentration: 7940 nM
The estimate for compound 3 lay 2.3-fold (0.36 log units) below the measured number, within the range that was stated.
By their numbers in this assay, from the lowest: compound 1; then compounds 2 and 3 (each within the scatter of the next).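

In this assay, for the compounds shown here, the methyl on an oxygen on an aromatic ring can be exchanged for the group of 7 heavy atoms, with its five-membered aromatic ring and defined stereocentre, with only a 1.6-fold higher number from compound 2 to compound 3 (0.20 log units; within the scatter), so this much added bulk at that oxygen produces no step that can be told from the scatter. Measured against the chloro of compound 1, the same ether gives a 4.0-fold higher number from compound 1 to compound 3 (0.60 log units; beyond the scatter), beyond the scatter and in the same direction as the methoxy exchange, a 2.5-fold higher number from compound 1 to compound 2 (0.40 log units; beyond the scatter), so neither ether at this position matches the chloro. No accompanying data bear on these steps, and the numbers alone cannot explain them.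

Still open, as far as these compounds go, is how the opposite configuration at the stereocentre would read, and whether the five-membered aromatic ring contributes anything beyond what the methyl gives. From the compounds shown here alone, it is also open whether an ethyl group, a phenyl ring or a chain carrying an amine on the same oxygen would bring the number down to that of compound 1, which gives 2000 nM.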